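The source may report more compounds than this note shows. Statements on the series, on what has been measured and on what is new or still open speak of the compounds shown alone.

Going by the values given here, compound 2 `CC1CCN(c2c(S(=O)(=O)c3ccc(Cl)c(Cl)c3)cnc3c(F)cccc23)CC1` sits at the higher of the two numbers measured in an assay on isolated protein for displacement of a labelled ligand from metabotropic glutamate receptor 5 (Homo sapiens), with a stated time of 60 min, tested at 1 uM (on this read-out lower numbers stand for less inhibition and higher numbers for more inhibition at the one concentration tested (going by the name of the read-out)), where compound 2 gives 95%, although the gap to its only neighbour is within the scatter: compound 1 `Cc1ccc(S(=O)(=O)c2cnc3c(F)cccc3c2N2CCC(C)CC2)cc1` gives 93% in this assay. Among the compounds with values here, the one measured step, a number 2 percentage points higher from compound 1 to compound 2 (within the scatter), concerns the same aryl group on the sulfonyl sulfur and stayed within the scatter. Compound 3 `CC1CCN(c2c(S(=O)(=O)c3ccc(F)c(Cl)c3)cnc3c(F)cccc23)CC1` differs from compound 2 by fluoro in place of chloro on an aromatic carbon. This swap of one halogen for another on the same ring is a smaller change than the exchange of the whole aryl group already seen, so no movement beyond the scatter is expected in this assay because a number 2 percentage points higher from compound 1 to compound 2 (within the scatter) itself lay within it, and the expected step is a number 3 percentage points lower from compound 2 to compound 3 (within the scatter). Compound 3 is therefore estimated at 92% in this assay, expected to fall between 84% and 98%.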

Compound 3, a percentage reported as inhibition, at one concentration (the size of the read-out at that concentration, not a potency): 95%
Beside the measured number, compound 3's estimate is 3 percentage points below it; low and high end bracket the measured number.
By their numbers in this assay, from the lowest: compounds 1, 2 and 3 (each within the scatter of the next).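

The halogen on the aromatic carbon para to a large group can be exchanged without a step beyond the scatter: in this assay the swap of chloro for fluoro gives no change at the digits printed from compound 2 to compound 3 (within the scatter) and so leaves the two halogens indistinguishable here. The 3-chloro-4-fluorophenyl group on the sulfonyl sulfur gives a number 2 percentage points higher from compound 1 to compound 3 (within the scatter) and thus joins 3,4-dichlorophenyl in showing no step beyond the scatter against 4-methylphenyl. Nothing given here explains why these aryl groups read alike.

From the compounds shown here alone, a reading at one concentration is not a potency, so whether the three compounds differ in potency stays open. Also open, going by these compounds, is how an amine or a carboxylic acid in place of the fluoro would read in this assay on this ring.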